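The compounds below may be only part of what the source reports. "The series", "measured", "known", "first", "only" and "open" are said of these compounds alone.

Compound 1 `COC(=O)c1cccc(C2C(C(=O)O)=C(C)N=C(C)/C2=C(/O)OC/C=C/c2ccccc2)c1`: 4400 nM in a functional assay on thoracic aorta for inhibition of Voltage-gated L-type calcium channel (Rattus norvegicus); on this read-out lower numbers stand for stronger inhibition and higher numbers for weaker inhibition.
Compound 2 `CC1=NC(C)=C(C(=O)O)C(c2cccc(Cl)c2)/C1=C(\O)OC/C=C/c1ccccc1`: 20 nM in this assay.

Among the measured compounds shown here, of these two numbers, compound 2 holds the lower one; the only measured step is a 220-fold lower number from compound 1 to compound 2 (2.34 log units; beyond the scatter). Compound 3 `CC1=NC(C)=C(C(=O)O)C(c2cccc(Cl)c2)/C1=C(\O)OC/C=C/C1CCCCC1` differs from compound 2 by cyclohexyl in place of phenyl on a double-bonded chain carbon bound to a double-bonded chain carbon. For the measured compounds named here, that step sits on the aromatic carbon of the other ring, so no measured step bears on the change to the chain, and nothing beyond the scatter is expected. Compound 3 is therefore expected to give 30 nM in this assay, within 8 nM to 110 nM, an expected step of a 1.5-fold higher number from compound 2 to compound 3 (0.18 log units; within the scatter).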

Compound 3, half-maximal inhibitory concentration: 3.7 nM
Compound 3: the middle estimate sits 8.1-fold (0.91 log units) above what was measured, outside the stated range (below it).
By their numbers in this assay, from the lowest: compound 3; then compound 2; then compound 1.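

Aromatic character in this ring is not required for inhibition in this assay since replacing phenyl with cyclohexyl, a non-aromatic ring of the same six carbons, gives a 5.4-fold lower number from compound 2 to compound 3 (0.73 log units; beyond the scatter) and the number does not rise. Among the compounds shown here, the earlier step lay on the other ring, so this is the first sign that the far end of the chain also affects the read-out. Nothing measured here accounts for this step. Going by these compounds, whether cyclopentyl, an open hexyl chain or a cyclohexyl ring carrying an amine would match cyclohexyl stays open.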